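Sulfonyl aryl swaps in a quinoline series: clearance

The source may hold more compounds than are shown below. What is called first, only, known or untested is meant among the compounds shown, and "the series" means these compounds.

Measured compounds:
- compound 1, `COc1ccc(-c2c(S(=O)(=O)c3ccc(F)c(Cl)c3)cnc3cc(F)ccc23)cc1`: 1.08 mL/min
- compound 2, `COc1cccc(-c2c(S(=O)(=O)c3cccc(C#N)c3)cnc3cc(F)ccc23)c1`: 1.83 mL/min
- compound 3, `COc1ccc(-c2c(S(=O)(=O)c3cc(Cl)cc(Cl)c3)cnc3cc(F)ccc23)cc1`: 1 mL/min

All three were run in an ADME assay on microsomes from liver (Homo sapiens) for metabolic stability, tested at 2.5 uM; on this read-out higher numbers stand for fast clearance and lower numbers for slow clearance. Compound 3 shows the smallest number of the three, yet neither gap reaches beyond the usual scatter: the nearest neighbour is compound 1 and the furthest is compound 2, and both differences fall inside the repeat variability of this assay.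

Compound 4, `COc1ccc(-c2c(S(=O)(=O)c3cccc(C#N)c3)cnc3cc(F)ccc23)cc1`, has not been measured. Relative to compound 3 it differs in one place: 3-cyanophenyl in place of 3,5-dichlorophenyl on a sulfonyl sulfur

For the measured compounds named here, one measured step bears directly on this position. Exchanging one substituted phenyl for another on the sulfonyl sulfur gave a 1.1-fold lower number from compound 1 to compound 3 (0.03 log units; within the scatter), so a change at this point left this assay essentially unmoved. Going by the values given here, compound 2 already carries the 3-cyanophenyl that enters in compound 4, though its other aryl group differs, so no single-point step links it to compound 3; its value and that of compound 3 sit within scatter of each other. On this basis no shift beyond the scatter is expected, the estimated step being a 1.3-fold higher number from compound 3 to compound 4 (0.11 log units; within the scatter).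

Compound 4 is therefore expected to give about 1.3 mL/min in this assay, with a likely range of 0.7 mL/min to 2.4 mL/min.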

Compound 4, intrinsic clearance in a liver preparation (reported as CLH), per the amount of preparation that the assay uses: 0.92 mL/min
The estimate for compound 4 lay 1.4-fold (0.15 log units) above the measured number; measured number inside the range.
By their numbers in this assay, from the lowest: compounds 4, 3, 1 and 2 (each within the scatter of the next).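

With the 4-methoxyphenyl held constant, three aryl groups on the sulfonyl sulfur can now be compared directly in this assay: 3-cyanophenyl in place of 3,5-dichlorophenyl gives a 1.1-fold lower number from compound 3 to compound 4 (0.04 log units; within the scatter) and 3-cyanophenyl in place of 3-chloro-4-fluorophenyl gives a 1.2-fold lower number from compound 1 to compound 4 (0.07 log units; within the scatter), so a ring bearing a nitrile and rings bearing only halogens cannot be told apart at this position. The other aryl group also gains its first single-point comparison, as 4-methoxyphenyl in place of 3-methoxyphenyl on an aromatic carbon gives a 2.0-fold lower number from compound 2 to compound 4 (0.30 log units; within the scatter), so the methoxy placement, like the sulfonyl aryl swaps, produces no step beyond the scatter. Nothing available bears on why these steps remain within the scatter.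

Going by these compounds, all four compounds keep an aryl ring on the sulfonyl sulfur and a methoxyphenyl on the shared core, so it remains open whether a saturated amine such as piperidine or morpholine in place of that aryl ring, or a carboxylic acid on it, would move the clearance beyond the scatter. On these data alone, it is equally open whether a hydroxyl or a longer alkoxy chain in place of the methoxy group would do so.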